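Methyl Added to the Core of Compound 1

The source may report more compounds than this note shows. Statements on the series, on what has been measured and on what is new or still open speak of the compounds shown alone.

Compound 1 `Cc1cc2cc(OCC(=O)O)ccc2n1Cc1ccc(O)c(C(C)C)c1`: 1.12 nM
Compound 2 `Cc1cn(Cc2ccc(O)c(C(C)C)c2)c2ccc(OCC(=O)O)cc12`: 0.38 nM
Compound 3 `CC(C)c1cc(Cn2ccc3cc(OCC(=O)O)cc(Cl)c32)ccc1O`: 0.07 nM

In an assay on HeLa cells for displacement of a labelled ligand from thyroid hormone receptor beta (Homo sapiens) (a higher number here means a weaker inhibitor, a lower number a stronger inhibitor), compound 1 gives 1.12 nM, the highest of the three numbers. Compound 2 gives 0.38 nM, beyond the scatter below compound 1, and compound 3 gives 0.07 nM, further below it still. Compound 4 `Cc1cc(OCC(=O)O)cc2cc(C)n(Cc3ccc(O)c(C(C)C)c3)c12` differs from compound 1 by methyl in place of hydrogen on an aromatic carbon. Within the data shown here, no pair of measured compounds differs in this one place alone; compound 3 carries a chlorine on its core but differs from compound 1 in more than one place, so its value alone cannot tell what this methyl will do. A modest downward step is expected, a 2.2-fold lower number from compound 1 to compound 4 (0.35 log units; beyond the scatter). Compound 4 is therefore estimated at 0.5 nM, with a range from 0.15 nM to 1.5 nM.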

Compound 4, inhibition constant: 0.14 nM
Compound 4: middle estimate off by 3.6-fold (0.55 log units), on the high side; the measured number lies below the stated range.
By their numbers in this assay, from the lowest: compounds 3 and 4 (each within the scatter of the next); then compound 2; then compound 1.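

In this assay a methyl on an aromatic carbon, meta to the carboxymethoxy group, gives an 8.0-fold lower number from compound 1 to compound 4 (0.90 log units; beyond the scatter) on the core of compound 1. Among these compounds, this is the first reading of a change at this position alone, and it shows that the position accepts a methyl and that the number falls beyond the scatter. Nothing at hand explains the size of this step.

The compounds shown leave open whether this gain is particular to methyl. An ethyl or a methoxy group at this position would test that.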